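Swapping the aromatic ring on the amine nitrogen

The source may hold more compounds than are shown below. What is called first, only, known or untested is meant among the compounds shown, and "the series" means these compounds.

Of the compounds shown here, three sharing one core have been tested in a functional assay on LNCaP cells (Homo sapiens) for antiproliferative activity, read by CCK-8 assay, with a stated time of 6 days; on this read-out lower numbers stand for stronger inhibition and higher numbers for weaker inhibition. Compound 1 `C[C@@H](Cn1ccc(-c2ccc(C#N)c(Cl)c2)n1)NC(=O)C1CC(=O)C1` gives 3040 nM, compound 2 `C[C@@H](Cn1ccc(-c2ccc(C#N)c(Cl)c2)n1)Nc1ccccc1` gives 710 nM, and compound 3 `C[C@@H](Cn1ccc(-c2ccc(C#N)c(Cl)c2)n1)Nc1cccnc1` gives 430 nM, the lowest number of the three, though compound 2 sits within the scatter of it. Compound 4 `Cc1ccnc(N[C@@H](C)Cn2ccc(-c3ccc(C#N)c(Cl)c3)n2)n1` differs from compound 3 by 4-methylpyrimidin-2-yl in place of pyridin-3-yl on an amine nitrogen. Within the data shown here, the only measured step that changes the aromatic ring on this nitrogen is a 1.7-fold lower number from compound 2 to compound 3 (0.22 log units; within the scatter), which did not move the number beyond the scatter. A step of similar small size is therefore expected from compound 3 to compound 4 in this assay, a 1.1-fold lower number from compound 3 to compound 4 (0.03 log units; within the scatter), with no direction secured. Compound 4 is accordingly estimated at 400 nM, within a range of 130 nM to 1200 nM.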

Compound 4, half-maximal inhibitory concentration: 1330 nM
Estimate against measurement, compound 4: 3.3-fold (0.52 log units) below, and the stated range ends below it.
By their numbers in this assay, from the lowest: compounds 3, 2 and 4 (each within the scatter of the next, the first and the last beyond it); then compound 1.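

The choice of aromatic ring on this amine nitrogen can matter: a 3.1-fold higher number from compound 3 to compound 4 (0.49 log units; beyond the scatter) lies beyond the scatter, which the earlier ring swap did not. Against phenyl, a 1.9-fold higher number from compound 2 to compound 4 (0.27 log units; within the scatter) stays within the scatter, while a 2.3-fold lower number from compound 1 to compound 4 (0.36 log units; beyond the scatter) still leaves 4-methylpyrimidin-2-yl ahead of the (3-oxocyclobutyl)carbonyl group. Nothing available explains why this change raises the number.

From the compounds shown here alone, the methyl group and the second ring nitrogen enter together in compound 4, so their separate contributions remain open. A plain pyrimidin-2-yl or a 4-methylpyridin-2-yl group on this nitrogen would pull them apart.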